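Bromo Replaces Hydrogen on the Phenyl of Compound 3

The compounds below may be only part of what the source reports. "The series", "measured", "known", "first", "only" and "open" are said of these compounds alone.

Within the data shown here, compound 3 `O=C(CCCCCCNC(=O)C(O)(O)C(F)(F)F)Nc1ncc(-c2ccccc2)s1` gives 2660 nM in a functional assay on HCT-116 cells (Homo sapiens) for inhibition, read by colorimetric assay, with a stated time of 3 days (a lower number here means a stronger inhibitor, a higher number a weaker inhibitor), the lowest of the three numbers measured so far. Where compound 3 carries phenyl, compound 1 `O=C(CCCCCCNC(=O)C(O)(O)C(F)(F)F)Nc1nccs1` has hydrogen, and in this assay compound 1 gives 10800 nM; the step is a 4.1-fold lower number from compound 1 to compound 3 (0.61 log units; beyond the scatter). Compound 2 `CCOc1ccc(-c2cnc(NC(=O)CCCCCCNC(=O)C(O)(O)C(F)(F)F)s2)cc1`, carrying 4-ethoxyphenyl in that place, gives 4050 nM in this assay, and the step of a 1.5-fold lower number from compound 2 to compound 3 (0.18 log units; within the scatter) lies within the scatter. Compound 4 `O=C(CCCCCCNC(=O)C(O)(O)C(F)(F)F)Nc1ncc(-c2ccc(Br)cc2)s1` differs from compound 3 by bromo in place of hydrogen on an aromatic carbon. Among the measured compounds shown here, the only measured step that bears on a change to the phenyl is a 1.5-fold lower number from compound 2 to compound 3 (0.18 log units; within the scatter), which was within the scatter, so no step beyond the scatter is expected in this assay. For compound 4 the expected step is a 1.1-fold lower number from compound 3 to compound 4 (0.03 log units; within the scatter). Compound 4 is therefore estimated at 2500 nM in this assay, within 1000 nM to 6000 nM.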

Compound 4, half-maximal inhibitory concentration: 2460 nM
Compound 4: the middle estimate sits 1.0-fold (0.01 log units) above what was measured, within the range that was stated.
By their numbers in this assay, from the lowest: compounds 4, 3 and 2 (each within the scatter of the next); then compound 1.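

Bromo in place of hydrogen, para to a large group, gives a 1.1-fold lower number from compound 3 to compound 4 (0.03 log units; within the scatter) in this assay, and bromo in place of ethoxy gives a 1.6-fold lower number from compound 2 to compound 4 (0.22 log units; within the scatter) at the same place. Hydrogen, ethoxy and bromo at this place are therefore not told apart in this assay. The 4-bromophenyl group still gives a 4.4-fold lower number from compound 1 to compound 4 (0.64 log units; beyond the scatter) against hydrogen on the shared core, as phenyl and 4-ethoxyphenyl also did. As far as these compounds go, whether an amine or a carboxylic acid at this place would move the number beyond the scatter remains open. Nothing shown accounts for these steps.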